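The compounds below may be only part of what the source reports. "The series", "measured", "known", "first", "only" and "open" are said of these compounds alone.

Working notes on the series. In a functional assay on MX1 cells (Homo sapiens) for antiproliferative activity, with a stated time of 72 h (a higher number here means that more compound is needed for the effect, a lower number that less compound is needed), compound 1 `Cc1cc(-c2ccccc2Oc2ccccc2)c[nH]c1=O` gives 2400 nM. Compound 2 `Cn1cc(-c2ccccc2Oc2ccccc2)cc(N)c1=O` is reported only as a limit, > 5000 nM. Compound 3 `Cn1cc(-c2cc(NS(C)(=O)=O)ccc2Oc2ccccc2C(F)(F)F)c2cc[nH]c2c1=O` gives 83 nM, the lower of the two actual numbers in this assay, and its gap to compound 1 lies well beyond the scatter.

The next compound to examine is compound 4 `Cn1cc(-c2cc(NS(C)(=O)=O)ccc2Oc2ccc(F)cc2F)c2cc[nH]c2c1=O`. It differs from compound 3 in one place only, with 2,4-difluorophenyl in place of 2-(trifluoromethyl)phenyl on an oxygen on an aromatic ring. The rest of the structure is unchanged.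

For the measured compounds named here, no pair of measured compounds differs at this place alone, so the series offers no direct measure of such a change. Compounds 1 and 2 also carry a different group on that oxygen, but they differ from compound 3 elsewhere as well, and they cannot isolate its contribution. The expectation is therefore a judgement, anchored on compound 3 at 83 nM. A moderate shift toward a lower number is expected, though the range allows for no change beyond the scatter. The estimated step is a 2.8-fold lower number from compound 3 to compound 4 (0.44 log units; beyond the scatter). In this assay, the expected value for compound 4 is 30 nM, with an estimated range of 8 nM to 100 nM.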

Compound 4, half-maximal effective concentration: 29 nM
The estimate for compound 4 lay 1.0-fold (0.01 log units) above the measured number, and the stated range covers the measured number.
By their numbers in this assay, from the lowest: compound 4; then compound 3; then compound 1. At a limit, above all of these: compound 2.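

The place on an oxygen on an aromatic ring now has its first single-place reading in this assay: 2,4-difluorophenyl in place of 2-(trifluoromethyl)phenyl gives a 2.9-fold lower number from compound 3 to compound 4 (0.46 log units; beyond the scatter), a modest step but one beyond the scatter. It also shows that, on this core, the trifluoromethyl group is not required for a low number, since compound 4, which carries only ring fluorines and has the lower heavy-atom count in this group, gives 29 nM. Nothing measured for these compounds accounts for the size or direction of the step.

With one step at this place, the compounds shown leave open whether the two fluorines of 2,4-difluorophenyl act together or whether one of them alone would give the same reading. They also leave open how an amine or a carboxylic acid on this ring, or a saturated cyclohexyl ring in its place, would read in this assay, and whether the same exchange would give a step of similar size on the core of compound 1.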